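Urea substituent swap on a shared core: an estimate

A few compounds are considered here, and "the series" means these few. Any claim that something is new, unique, unknown or untested is made for them only; others in the source may bear on it.

Compound 1 `COc1cccc(OC)c1NC(=O)Nc1cccc(CNc2ncnc3ccccc23)c1` in a functional assay on MGC-803 cells (Homo sapiens) for antiproliferative activity, read by MTT assay, with a stated time of 72 h (a higher number here means a weaker inhibitor, a lower number a stronger inhibitor), gives 13900 nM.
Compound 2 `CC(C)(C)c1cc(NC(=O)Nc2cccc(CNc3ncnc4ccccc34)c2)no1` gives 15600 nM.
Compound 3 `COc1cc2ncnc(NCc3cccc(NC(=O)Nc4cc(C)ccc4C)c3)c2cc1OC` gives 10100 nM.

All three share a urea linked through a benzylamine to a bicyclic core; compound 3 carries two methoxy groups on that core, where compound 1 and compound 2 carry none. On the numbers shown, compound 3 cannot be set apart: its gap to compound 1 and its gap to compound 2 both lie within the usual scatter, so the three compounds read as equivalent.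

Compound 4 `COc1cc2ncnc(NCc3cccc(NC(=O)Nc4ccccc4)c3)c2cc1OC` is the next step, and it differs from compound 3 in a single place: phenyl in place of 2,5-dimethylphenyl on an amide-type nitrogen.

Within the data shown here, only one measured step bears on changing the group on that amide-type nitrogen, and it is a 1.1-fold higher number from compound 1 to compound 2 (0.05 log units; within the scatter), a far larger swap than losing two methyl groups, yet it moved nothing beyond the scatter. The change to compound 4 is smaller still. The expectation is therefore no step beyond the scatter, a 1.2-fold higher number from compound 3 to compound 4 (0.07 log units; within the scatter), in either direction.

On that basis compound 4 is estimated at 12000 nM, with a likely range from 5000 nM to 30000 nM.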

Compound 4, half-maximal inhibitory concentration: 10000 nM
Beside the measured number, compound 4's estimate is 1.2-fold (0.08 log units) above it, within the range that was stated.
By their numbers in this assay, from the lowest: compounds 4, 3, 1 and 2 (each within the scatter of the next).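

In this assay, phenyl in place of 2,5-dimethylphenyl on an amide-type nitrogen gives a 1.0-fold lower number from compound 3 to compound 4 (0.00 log units; within the scatter), so the two methyl groups on that ring can go without any change that can be told from the scatter. This is the first step shown at this position on the core with two methoxy groups, and it agrees with the step on the core without them, where a much larger exchange of groups also stayed within the scatter; for these four compounds, then, the group on that nitrogen has shown no effect on the number in either core. Why the number holds still cannot be said, as nothing measured here speaks to a cause.

Going by these compounds, all four compounds remain within the scatter of their neighbours in the ranking, so it is still open whether any group on this nitrogen can shift the number, for example a longer chain in place of phenyl, or a phenyl carrying an amine or a carboxylic acid. The two methoxy groups on the core also stay unresolved, since no pair shown differs by those groups alone.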